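The source may hold more compounds than are shown below. What is called first, only, known or untested is meant among the compounds shown, and "the series" means these compounds.

Of the compounds shown here, three sharing one core have been measured in an assay on HEK293 cells for displacement of a labelled ligand from NPC1-like intracellular cholesterol transporter 1 (Homo sapiens); a higher number here means a weaker inhibitor, a lower number a stronger inhibitor. Compound 1 `CCOC(=O)C1CCN(C(=O)CN2CN(c3ccccc3)C3(CCN(C(=O)c4ccc(C5CCCCC5)cc4)CC3)C2=O)CC1` gives 900 nM. Compound 3 `O=C(CN1CN(c2ccccc2)C2(CCN(C(=O)c3ccc(C4CCCCC4)cc3)CC2)C1=O)N1CCCCC1`, which differs from compound 1 only by the change summarised as a 1.2-fold higher number from compound 1 to compound 3 (0.09 log units; within the scatter), gives 1100 nM. Compound 2 `CC(C)(C)c1ccc(C(=O)N2CCC3(CC2)C(=O)N(CC(=O)NCCO)CN3c2ccccc2)cc1` gives 1000 nM; its value and those of compound 1 and compound 3 all lie within the usual scatter of one another, so on these numbers compound 2 cannot be told apart from either of the others.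

Compound 4 `CC(C)(C)c1ccc(C(=O)N2CCC3(CC2)C(=O)N(CC(=O)NCNS(C)(=O)=O)CN3c2ccccc2)cc1` is derived from compound 2 by a single change: methanesulfonamido in place of hydroxymethyl on a saturated chain carbon bound to an amide-type nitrogen. Within the data shown here, no measured pair shows this particular exchange, so no step speaks to it directly. Among the measured compounds shown here, the only step between measured compounds, from compound 1 to compound 3, alters a different part of the molecule and stays within the scatter, and the three measured compounds give much the same number despite their differences. With nothing pointing in either direction, the expected step in this assay is no change at the digits printed from compound 2 to compound 4 (within the scatter), which amounts to no change beyond the scatter. Compound 4 is therefore estimated at 1000 nM, with a likely range from 400 nM to 2500 nM.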

Compound 4, half-maximal inhibitory concentration: 3200 nM
The estimate for compound 4 lay 3.2-fold (0.51 log units) below the measured number; measured number above the stated range.
By their numbers in this assay, from the lowest: compounds 1, 2 and 3 (each within the scatter of the next); then compound 4.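

In this assay, replacing hydroxymethyl with methanesulfonamido on a saturated chain carbon bound to an amide-type nitrogen gives a 3.2-fold higher number from compound 2 to compound 4 (0.51 log units; beyond the scatter), so compound 4 is the weaker inhibitor by a modest but real margin. Among these compounds, the only earlier step, a 1.2-fold higher number from compound 1 to compound 3 (0.09 log units; within the scatter), sits in a different part of the molecule and stays within the scatter, so this is the first sign that a single change can move the number, and that this position is not indifferent to what it carries. The entering group has 5 heavy atoms where the leaving group has 2, and it brings in sulfur and nitrogen, but nothing measured here says which of these differences, if any, accounts for the rise.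

The compounds shown leave open whether a plain amine or a carboxylic acid at this position would stay close to compound 2 or fall nearer compound 4. They also do not settle whether a longer chain carrying methanesulfonamido would give a different number, or whether the same exchange would have a similar effect on the cyclohexyl-bearing compounds.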